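This account rests on a few compounds, and the source may have more. Where it says the series, first, only, none or still open, it means among the compounds named here.

Series notes, measured so far in an ADME assay on a cell-free system (plasma, Homo sapiens) for metabolic stability, read by HPLC; a lower number here means that the compound disappears faster, a higher number that the compound lasts longer:

- compound 1 `CN(/N=N/c1ccc(C#N)cc1)C(=O)CCc1ccc(O)cc1`: 5.8 h
- compound 2 `COC(=O)c1ccc(/N=N/N(C)C(=O)CCc2cccc(O)c2)cc1`: 7.8 h

In this assay, within the data shown here, compound 2 gives 7.8 h, and this value lies within the scatter of the one for compound 1, 5.8 h. The two measured compounds therefore cannot be separated on these numbers, and both sit in a narrow band of half-lives.

The next compound is compound 3 `CN(/N=N/c1ccc(C#N)cc1)C(=O)CCc1cccc(O)c1`. Relative to compound 2, it has cyano in place of methoxycarbonyl on an aromatic carbon, para to a large group (cyano in place of methoxycarbonyl on an aromatic carbon). Among the measured compounds shown here, no measured pair differs in one place only, so this exchange has no direct precedent. For the measured compounds named here, the only guide is that compound 1, which also carries a cyano, gives 5.8 h, close to compound 2 at 7.8 h. On that limited basis, no change beyond the scatter is expected in this assay, and the expected result is a 1.2-fold lower number from compound 2 to compound 3 (0.08 log units; within the scatter). For compound 3 the estimated half-life is 6.5 h, with an expected range of 3.5 h to 12 h.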

Compound 3, half-life in the plasma assay: 2.7 h
Compound 3: middle estimate off by 2.4-fold (0.38 log units), on the high side, outside the stated range (below it).
By their numbers in the plasma assay, from the lowest: compound 3; then compounds 1 and 2 (each within the scatter of the next).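

Among these compounds, in the plasma assay compound 3 gives 2.7 h, and the exchange of methoxycarbonyl for cyano on an aromatic carbon, para to a large group, gives a 2.9-fold lower number from compound 2 to compound 3 (0.46 log units; beyond the scatter), the first reading of a single change at this position. The earlier pair differs in more than one place and could not provide this reading. The second single change, 3-hydroxyphenyl in place of 4-hydroxyphenyl on a saturated chain carbon, two bonds along the chain from a carbonyl carbon, gives a 2.1-fold lower number from compound 1 to compound 3 (0.33 log units; beyond the scatter), so the number responds at that place as well. In a physicochemical assay for metabolic stability, read by HPLC, in phosphate buffer, at pH 7.4 (on this read-out lower numbers stand for a shorter-lived compound and higher numbers for a longer-lived compound), compound 2 gives 94.7 h and compound 3 gives 60.1 h, and the cyano exchange gives a 1.6-fold lower number from compound 2 to compound 3 (0.20 log units; within the scatter), so it separates the two compounds only in the plasma assay.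

No measurement on hand accounts for either step. From the compounds shown here alone, it remains open whether the shorter half-life of compound 3 tracks cyano specifically or would also appear with another group at that aromatic carbon, such as a carboxylic acid, and whether the effect of moving the hydroxyl holds when methoxycarbonyl is present.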